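The compounds below may be only part of what the source reports. "The series", "measured", "known", "first", "only" and "open" are said of these compounds alone.

Compound 1, `Cc1ccc(Oc2ccc(/C=N/NC(=O)CSc3nc4ccccc4s3)cc2)cc1`, gives 5.7 in a physicochemical assay for lipophilicity, in phosphate buffer, measured as octanol-water partition, with a stated time of 24 h; on this read-out higher numbers stand for higher lipophilicity and lower numbers for lower lipophilicity.
Compound 2, `Cc1cc(Oc2ccc(/C=N/Nc3nc4ccccc4s3)cc2)ccc1Cl`, gives 5.5 in this assay.

Compound 1 has the higher of the two numbers, but compound 2 lies within the scatter of it, so the two cannot be told apart on this read-out. Among the compounds with values here, no pair of measured compounds differs in just one place, so no single change has yet been followed.

Compound 3, `O=C(CSc1nc2ccccc2s1)N/N=C/c1ccc(Oc2ccc(Br)cc2)cc1`, is the unmeasured compound. It differs from compound 1 by bromo in place of methyl on an aromatic carbon, a swap of one heavy atom for another with no ring, no hydrogen-bond donor or acceptor, and no charge involved.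

Within the data shown here, with no comparable step among the measured compounds to lean on, the step from compound 1 to compound 3 is expected to be small, at most at the edge of the scatter, and if anything upward. Compound 3 is therefore estimated at 5.9, with a likely range from 5.5 to 6.3, and an expected step of a number 0.20 log units higher from compound 1 to compound 3 (within the scatter).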

Compound 3, partition coefficient: 5.7
Compound 3: the middle estimate sits 0.20 log units above what was measured, and the stated range covers the measured number.
By their numbers in this assay, from the lowest: compounds 2, 1 and 3 (each within the scatter of the next).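

Within the data shown here, this is the first change in the set that can be followed at a single place: with bromo in place of methyl on an aromatic carbon, para to a large group, this assay shows no change at the digits printed from compound 1 to compound 3 (within the scatter) and does not tell the two groups apart. The finding covers this one pair on the core of compound 1, so 4-methylphenoxy and 4-bromophenoxy can be treated as interchangeable on this read-out only at this place. No measurement at hand offers an explanation for this result.

As far as these compounds go, it remains open whether a group of a different kind at the same place, such as an amine or a carboxylic acid, would shift the number beyond the scatter. Also open, from the compounds shown here alone, is whether the same swap of methyl for bromo would read the same way at another place on the core or on the core of compound 2.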